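Swapping 3-(trifluoromethyl)phenyl for 4-methoxyphenyl: a cytotoxicity estimate

A few compounds are considered here, and "the series" means these few. Any claim that something is new, unique, unknown or untested is made for them only; others in the source may bear on it.

Compound 1 `Cc1cc(S(N)(=O)=O)ccc1NC(=O)COc1ccc(Cl)cc1NC(=O)c1cccc([N+](=O)[O-])c1`: 58800 nM
Compound 2 `Cc1cc(S(N)(=O)=O)ccc1NC(=O)COc1ccc(Cl)cc1NC(=O)c1cccc(C(F)(F)F)c1`: 124000 nM

In a functional assay on C8166 cells (Homo sapiens) for cytotoxicity, read by MTT assay (a lower number here means that less compound is tolerated, a higher number that more compound is tolerated), compound 2 stands higher of the two measured compounds, at 124000 nM. Compound 3 `COc1ccc(C(=O)Nc2cc(Cl)ccc2OCC(=O)Nc2ccc(S(N)(=O)=O)cc2C)cc1` carries 4-methoxyphenyl in place of 3-(trifluoromethyl)phenyl on a carbonyl carbon. Among the compounds with values here, only one measured step bears on this change: a 2.1-fold higher number from compound 1 to compound 2 (0.32 log units; beyond the scatter), a modest step with trifluoromethyl in place of nitro. Within the data shown here, no measured compound carries 4-methoxyphenyl, so this is weak guidance. A similarly modest step to a lower number is expected, estimated as a 1.5-fold lower number from compound 2 to compound 3 (0.16 log units; within the scatter). For compound 3, the estimated value is 85000 nM, with a range from 35000 nM to 210000 nM.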

Compound 3, half-maximal cytotoxic concentration: 69500 nM
Beside the measured number, compound 3's estimate is 1.2-fold (0.09 log units) above it; the measured number falls inside the stated range.
By their numbers in this assay, from the lowest: compounds 1, 3 and 2 (each within the scatter of the next, the first and the last beyond it).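

In this assay the change to 4-methoxyphenyl gives a 1.8-fold lower number from compound 2 to compound 3 (0.25 log units; within the scatter) and, against the nitro analogue, a 1.2-fold higher number from compound 1 to compound 3 (0.07 log units; within the scatter) and so compound 3 cannot be told apart from either compound 1 or compound 2, although those two differ beyond the scatter. At this carbonyl carbon, a ring carrying methoxy therefore falls within the range already spanned by the nitro and trifluoromethyl rings. As far as these compounds go, it remains open whether a ring bearing an amine or a carboxylic acid at this carbonyl carbon would stay in that range. No measurement shown here offers an explanation for these numbers.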